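A benzoyl group gives way to (thiophen-2-yl)methyl

A few compounds are considered here, and "the series" means these few. Any claim that something is new, unique, unknown or untested is made for them only; others in the source may bear on it.

Of the compounds shown here, three sharing one core have been tested in a functional assay on A549 cells (Homo sapiens) for cytotoxicity, with a stated time of 60 h; on this read-out lower numbers stand for an effect already at smaller amounts and higher numbers for an effect only at larger amounts of compound: compound 1 `CCN(CC)C(=O)c1c(NC(=O)c2cncs2)sc2c1CCCC2`, compound 2 `CCN(CC)C(=O)c1c(NC(=O)c2ccco2)sc2c1CCCC2` and compound 3 `CCN(CC)C(=O)c1c(NC(=O)c2ccccc2)sc2c1CCCC2`. Compound 1 reads > 30000 nM, which is a limit of the assay. Compound 2 reads > 30000 nM, again a limit. Compound 3 reads > 30000 nM, also a limit, so it has no number of its own. The whole set thus rests on (the limit of > 30000 nM in this assay, at which 3 of the 3 values shown sit).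

Compound 4 `CCN(CC)C(=O)c1c(NCc2cccs2)sc2c1CCCC2` has not yet been measured. Its difference from compound 3 is (thiophen-2-yl)methyl in place of benzoyl on a nitrogen on an aromatic ring. The nearest measured steps are a step that the two limits leave unreadable from compound 1 to compound 3 and a step that the two limits leave unreadable from compound 2 to compound 3. Within the data shown here, both only exchange the group on a carbonyl carbon, and no measured compound lacks the benzoyl-type carbonyl, so they give no size to carry over. With nothing shown that points to a change, the estimated step is a number no higher from compound 3 to compound 4 (the limit leaves the size open). For compound 4 the expected value in this assay is 30000 nM, with an estimated range of 10000 nM to 60000 nM.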

Compound 4, half-maximal effective concentration: > 30000 nM
Compound 4: a limit, no number (the forecaster's own chance of this, stated with the estimate: 80%); the middle value sits exactly at the limit.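

Compound 4, like compound 1, compound 2 and compound 3, gives only a limit, so none of its steps to these compounds can be read: (the limit of > 30000 nM in this assay, at which 4 of the 4 values shown sit). The compounds shown leave open whether any change on the shared core would give a measurable value in this assay.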